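Swapping the sulfinyl chain for an ethyl ester

The source may report more compounds than this note shows. Statements on the series, on what has been measured and on what is new or still open speak of the compounds shown alone.

Measured compounds:
compound 1, `Nc1c([S+]([O-])CCCF)sc2nc(-c3cccs3)cc(-c3ccccc3)c12` — 6.1 nM
compound 2, `CCCC[S+]([O-])c1sc2nc(-c3nccs3)cc(-c3ccc(COC(=O)CN(C)C)cc3)c2c1N` — 3.5 nM

Both compounds were tested in an assay for inhibition of 15-hydroxyprostaglandin dehydrogenase [NAD(+)] (Homo sapiens), read by fluorescence, with a stated time of 15 min, in the presence of a further agent that is not named here; on this read-out higher numbers stand for weaker inhibition and lower numbers for stronger inhibition. Compound 1 gives 6.1 nM and compound 2 gives 3.5 nM; compound 1 has the higher number of the two, but the gap between them lies within the scatter of repeated measurements, so the two values cannot be told apart.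

Compound 3, `CCOC(=O)c1sc2nc(-c3cccs3)cc(-c3ccccc3)c2c1N`, has not yet been measured. It differs from compound 1 in one place: a group of 5 heavy atoms (3 carbon, 2 oxygen; no ring) in place of a group of 6 heavy atoms (3 carbon, 1 oxygen, 1 fluorine, 1 sulfur; no ring), on an aromatic carbon. In words, a group of 5 heavy atoms (3 carbon, 2 oxygen; no ring) takes the place of a group of 6 heavy atoms (3 carbon, 1 oxygen, 1 fluorine, 1 sulfur; no ring), on an aromatic carbon.

Going by the values given here, no measured pair shows the effect of this change, so any expectation rests on the structures alone. Compound 3 is expected to give a weaker result, with the step of a 9.8-fold higher number from compound 1 to compound 3 (0.99 log units; beyond the scatter) going beyond the scatter. The estimated value for compound 3 is 60 nM, in a range from 10 nM to 400 nM.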

Compound 3, half-maximal inhibitory concentration: > 7500 nM
Compound 3: a limit, no number; the forecaster's own chance of this, stated with the estimate: 5%; at least 120-fold (2.09 log units) between middle value and limit.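

Compound 3 gives > 7500 nM in this assay, which is a limit of the assay and not a number: the limit of > 7500 nM in this assay, at which 1 of the 3 values shown sits. Putting ethoxycarbonyl in place of the sulfinyl chain, on the aromatic carbon next to the ring sulfur, brings an at least 1200-fold higher number from compound 1 to compound 3 (3.08 log units; beyond the scatter), so this place does not accept every group with a similar count of heavy atoms. Compound 1 and compound 2 both carry a sulfinyl chain here, so neither could show how much depends on this place.

The compounds shown leave open whether the sulfinyl group itself is needed or whether the ethoxycarbonyl group is what costs the inhibition. A sulfone, an amide or a carboxylic acid on this carbon, on the core of compound 1, would help to separate these two readings.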